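Replacing pyridin-3-yl in compound 2

The source may hold more compounds than are shown below. What is called first, only, known or untested is meant among the compounds shown, and "the series" means these compounds.

In an ADME assay on J774 cells (Mus musculus) for antiproliferative activity, with a stated time of 72 h (a higher number here means that more compound is needed for the effect, a lower number that less compound is needed), compound 1 `CCc1c(C)[nH]c2cc(OCCOc3ccccc3)c(C)cc2c1=O` gives only a limit of the assay, > 30000 nM. Within the data shown here, compound 2 `CCCCc1cc2c(=O)c(-c3cccnc3)c(C)[nH]c2cc1OCCOc1ccccc1` gives 23000 nM, the only actual number so far. Compound 3 `CCCCc1cc2c(=O)c(-c3ccc(C(F)(F)F)cc3C)c(C)[nH]c2cc1OCCOc1ccccc1` remains unmeasured. It carries 2-methyl-4-(trifluoromethyl)phenyl in place of pyridin-3-yl on an aromatic carbon, ortho to a methyl group and two atoms from the ring nitrogen. Among the measured compounds shown here, no measured step between two compounds is available, so the expectation in this assay rests on compound 2 at 23000 nM alone. No change beyond the usual scatter is expected, with a slight lean towards less compound being needed. The expected move is a 1.4-fold lower number from compound 2 to compound 3 (0.16 log units; within the scatter). A reading that reports only a limit also remains possible for compound 3. Compound 3 is estimated at 16000 nM, with an expected range of 6000 nM to 40000 nM.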

Compound 3, half-maximal effective concentration: 20000 nM
Beside the measured number, compound 3's estimate is 1.3-fold (0.10 log units) below it, and the stated range covers the measured number.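

In this assay, the aromatic carbon two atoms from the ring nitrogen now has its first readable step, with a 1.2-fold lower number from compound 2 to compound 3 (0.06 log units; within the scatter). The exchange of pyridin-3-yl for 2-methyl-4-(trifluoromethyl)phenyl adds heavy atoms and removes the hetero atom and hydrogen-bond acceptor of the leaving ring, yet the printed step stays within the scatter, so neither difference registers as a change in this pair. Compound 1 gives only a limit of the assay: the limit of > 30000 nM in this assay, at which 1 of the 3 values shown sits.

From the compounds shown here alone, it remains open whether any group at this position can move the number beyond the scatter, for example an amine or a carboxylic acid on the aromatic ring. A single pair also leaves open whether the same exchange would read alike on another core.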